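Two ortho-substitutions compared on a shared thienopyridine thiourea core

This account rests on a few compounds, and the source may have more. Where it says the series, first, only, none or still open, it means among the compounds named here.

Measured compounds:
compound 1, `NC(=O)c1c(NC(=O)c2ccccc2Br)sc2c1CCN(C(=S)Nc1ccccc1Cl)C2`, 14600 nM
compound 2, `NC(=O)c1c(NC(=O)c2ccccc2C(F)(F)F)sc2c1CCN(C(=S)Nc1ccccc1Cl)C2`, 17600 nM
compound 3, `NC(=O)c1c(NC(=O)c2ccccc2Br)sc2c1CCN(C(=S)Nc1ccccc1Br)C2`, 17600 nM

In a functional assay on HL-60 cells (Homo sapiens) for antiproliferative activity, with a stated time of 24 h (on this read-out lower numbers stand for stronger inhibition and higher numbers for weaker inhibition), the three measured compounds sit close together. The change from compound 1 to compound 2 is trifluoromethyl in place of bromo on an aromatic carbon, and it gave a 1.2-fold higher number from compound 1 to compound 2 (0.08 log units; within the scatter). The core of compound 3 differs from the core of compound 1 by bromo in place of chloro on an aromatic carbon, with a 1.2-fold higher number from compound 1 to compound 3 (0.08 log units; within the scatter). Compound 4, `NC(=O)c1c(NC(=O)c2ccccc2Br)sc2c1CCN(C(=S)Nc1ccccc1C(F)(F)F)C2`, is not yet measured; it differs from compound 3 by trifluoromethyl in place of bromo on an aromatic carbon, the same change as that made from compound 1 to compound 2, at a place described in the same words. Because the earlier instance of this change gave a 1.2-fold higher number from compound 1 to compound 2 (0.08 log units; within the scatter), the step from compound 3 to compound 4 in this assay is expected to be a 1.1-fold higher number from compound 3 to compound 4 (0.06 log units; within the scatter). Compound 4 is therefore estimated at 20000 nM, with a likely range from 10000 nM to 40000 nM.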

Compound 4, half-maximal inhibitory concentration: 27400 nM
The estimate for compound 4 lay 1.4-fold (0.14 log units) below the measured number; the range from low to high includes it.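

In this assay trifluoromethyl in place of bromo gave a 1.6-fold higher number from compound 3 to compound 4 (0.19 log units; within the scatter) and trifluoromethyl in place of chloro gave a 1.9-fold higher number from compound 1 to compound 4 (0.27 log units; within the scatter) on the shared core. Within the data shown here, this shows only that the same change gave steps that do not differ measurably on the two cores, and it does not show that the change has an effect of its own here or that it would carry to further cores. The two instances compare as follows: the same change on two cores in this assay, a 1.2-fold higher number (0.08 log units; within the scatter) from compound 1 to compound 2 and a 1.6-fold higher number (0.19 log units; within the scatter) from compound 3 to compound 4, 1.3-fold (0.11 log units) apart, within the scatter of two such steps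

The compounds shown leave open what an amine, a carboxylic acid or a methoxy group would do at these places on the aromatic rings. They also leave open whether any replacement there would give a step beyond the scatter.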